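From fluoro to methoxy: one step to estimate

The source may report more compounds than this note shows. Statements on the series, on what has been measured and on what is new or still open speak of the compounds shown alone.

compound 1 (`O=C1CCCCC/C1=C\c1ccc(F)cc1`) : 250000 nM
compound 2 (`O=C1CCCCC/C1=C\c1cccc(Cl)c1`) : 88600 nM
compound 3 (`O=C1CCCCC/C1=C\c1cccc(Br)c1`) : 176000 nM

All three numbers come from a functional assay on MOLT-4 cells (Homo sapiens) for inhibition; on this read-out higher numbers stand for weaker inhibition and lower numbers for stronger inhibition. In this set, compound 1 gives 250000 nM and sits at the upper end of the numbers. Compound 3, at 176000 nM, lies within the scatter of compound 1. Compound 2, at 88600 nM, has a lower number than compound 1, and that gap goes beyond the scatter.

The next compound to be measured is compound 4 (`COc1ccc(/C=C2\CCCCCC2=O)cc1`), which has methoxy in place of fluoro on an aromatic carbon of the core of compound 1 (methoxy in place of fluoro on an aromatic carbon). Among the measured compounds shown here, no measured step covers this exchange. For the measured compounds named here, neither fluoro nor methoxy is involved in the only step available, which puts bromo in place of chloro on an aromatic carbon: a 2.0-fold higher number from compound 2 to compound 3 (0.30 log units; within the scatter). That step gives only loose guidance, and it stays within the scatter. The three measured numbers also lie fairly close together. No step beyond the scatter is therefore expected in this assay, and no firm direction can be drawn from the data. The estimated outcome is a 1.4-fold lower number from compound 1 to compound 4 (0.14 log units; within the scatter). Compound 4 is expected at 180000 nM, with an estimated range from 70000 nM to 400000 nM.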

Compound 4, half-maximal inhibitory concentration: 250000 nM
The estimate for compound 4 lay 1.4-fold (0.14 log units) below the measured number; low and high end bracket the measured number.
By their numbers in this assay, from the lowest: compounds 2, 3, 1 and 4 (each within the scatter of the next, the first and the last beyond it).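

In this assay, putting methoxy in place of fluoro on an aromatic carbon, para to a group of 9 heavy atoms, gives no change at the digits printed from compound 1 to compound 4 (within the scatter). Among the compounds shown here, this is the first step read at this position, since the only earlier step, a 2.0-fold higher number from compound 2 to compound 3 (0.30 log units; within the scatter), exchanged chloro for bromo and involved neither fluoro nor methoxy. It shows that, in this one pair, replacing 1 heavy atom and no hydrogen-bond acceptor with 2 heavy atoms and 1 hydrogen-bond acceptor leaves the number unchanged, and nothing available offers an explanation for this result.

Going by these compounds, whether an amine or a carboxylic acid in place of fluoro on compound 1 would also leave the number unchanged remains open, so one pair cannot show how far this position accepts other groups. Also open, on these data alone, is whether methoxy would give the same result on the aromatic carbon that carries the chloro of compound 2, where the number is 88600 nM.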